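Shortening the Hydroxyalkyl Chain on a Shared Core

The source may hold more compounds than are shown below. What is called first, only, known or untested is meant among the compounds shown, and "the series" means these compounds.

Measured so far:
compound 1 `CCCS(=O)(=O)Nc1ccc(F)c(-c2cc3cnc(NCC4CC4)nc3n(C)c2=O)c1F` gives 61600 ng.h/mL
compound 2 `CCCS(=O)(=O)Nc1ccc(F)c(-c2cc3cnc(NCCCO)nc3n(C)c2=O)c1F` gives 9350 ng.h/mL

In an ADME assay on the whole organism (plasma) for pharmacokinetics, with Mus musculus as the target, at a dose of 30 mg/kg by the oral route (a higher number here means more compound in the circulation at the dose given, a lower number less compound in the circulation), compound 2 stands lowest of the two numbers shown, below compound 1 by the step of a 6.6-fold lower number from compound 1 to compound 2 (0.82 log units; beyond the scatter). Compound 3 `CCCS(=O)(=O)Nc1ccc(F)c(-c2cc3cnc(NCCO)nc3n(C)c2=O)c1F` differs from compound 2 by hydroxy in place of hydroxymethyl on a saturated chain carbon, two bonds along the chain from a nitrogen on an aromatic ring, so the 3-hydroxypropyl chain becomes 2-hydroxyethyl. Going by the values given here, the only measured step, from compound 1 to compound 2, swapped a cyclopropyl for a hydroxy-bearing chain; no step compares two hydroxyalkyl chains of different length. The change in compound 3 is therefore expected to give at most a small shift, a 1.2-fold lower number from compound 2 to compound 3 (0.07 log units; within the scatter), possibly within the scatter. Compound 3 is estimated at 8000 ng.h/mL, between 2500 ng.h/mL and 25000 ng.h/mL.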

Compound 3, area under the concentration-time curve: 453 ng.h/mL
Compound 3: the middle estimate sits 18-fold (1.25 log units) above what was measured; measured number below the stated range.
By their numbers in this assay, from the lowest: compound 3; then compound 2; then compound 1.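

In this assay, a small change in the length of the chain at this position has a large effect: shortening 3-hydroxypropyl to 2-hydroxyethyl gives a 21-fold lower number from compound 2 to compound 3 (1.31 log units; beyond the scatter). Replacing the cyclopropyl with hydroxymethyl at its position gives a 140-fold lower number from compound 1 to compound 3 (2.13 log units; beyond the scatter), and since compound 2 and compound 3 both end in a hydroxy yet lie far apart, that group alone does not set the number. Nothing available explains the sharp fall.

Still open, on these data alone, is whether a longer chain, such as 4-hydroxybutyl, would raise the number further. Also open, as far as these compounds go, is how an amine at the chain end would compare with the hydroxy.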